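This account rests on a few compounds, and the source may have more. Where it says the series, first, only, none or still open, it means among the compounds named here.

Measured compounds in an ADME assay on MT4 cells (Homo sapiens) for cytotoxicity, read by MTT assay, with a stated time of 5 days; on this read-out higher numbers stand for lower toxicity in this test and lower numbers for higher toxicity in this test:

compound 1 `O=C1N(Cc2ccc(Cl)cc2Cl)c2cccn2S(=O)(=O)N1Cc1ccccc1` gives 218000 nM
compound 2 `O=C1N(Cc2ccccc2Br)c2cccn2S(=O)(=O)N1Cc1ccccc1` gives 226000 nM
compound 3 `Cc1ccc(CN2C(=O)N(Cc3ccccc3)S(=O)(=O)n3cccc32)cc1` gives 241000 nM

Compound 3 shows the highest of the three numbers, but its separation from compound 2 and from compound 1 is within the scatter, so the three measured compounds are not distinguishable on this read-out. Going by the values given here, every step so far swaps the aryl group on the saturated chain carbon bound to the amide-type nitrogen in the ring and leaves the rest of the shared core untouched: a 1.0-fold higher number from compound 1 to compound 2 (0.02 log units; within the scatter), a 1.1-fold higher number from compound 1 to compound 3 (0.04 log units; within the scatter), a 1.1-fold higher number from compound 2 to compound 3 (0.03 log units; within the scatter). None of these exceeds the scatter.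

Compound 4 `N#Cc1cccc(CN2C(=O)N(Cc3ccccc3)S(=O)(=O)n3cccc32)c1` is not yet measured. The change from compound 3 is 3-cyanophenyl in place of 4-methylphenyl on a saturated chain carbon bound to an amide-type nitrogen in a ring. Among the compounds with values here, it sits at the same place as the three measured swaps, all of which were flat, though no measured step introduces a nitrile or any hydrogen-bond acceptor at this position, so that part of the change is untested. On the evidence of compound 3 and its flat neighbours the expected step is a 1.0-fold lower number from compound 3 to compound 4 (0.02 log units; within the scatter), that is, no change beyond the scatter. Compound 4 is therefore estimated at 230000 nM, with a range from 120000 nM to 450000 nM.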

Compound 4, half-maximal cytotoxic concentration: > 318000 nM
Compound 4: only a limit was reported (the forecaster's own chance of this, stated with the estimate: 20%); middle value at least 1.3-fold (0.14 log units) away from the limit.
By their numbers in this assay, from the lowest: compounds 1, 2 and 3 (each within the scatter of the next). At a limit, above all of these: compound 4.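

In this assay compound 4 is reported only as a limit and has no number of its own: the limit of > 318000 nM in this assay, at which 1 of the 4 values shown sits.

Against that limit the steps are floors, each of which lies within the scatter: an at least 1.3-fold higher number from compound 3 to compound 4 (0.12 log units; that floor lies within the scatter) and an at least 1.4-fold higher number from compound 2 to compound 4 (0.14 log units; that floor lies within the scatter) and an at least 1.4-fold higher number from compound 1 to compound 4 (0.16 log units; that floor lies within the scatter). What the earlier compounds did not show is that a nitrile can be carried on this aryl group, with 3-cyanophenyl replacing 4-methylphenyl on the saturated chain carbon bound to the amide-type nitrogen in the ring, without any sign of higher toxicity in this test, and that this is the first group here to reach the limit; a real separation from compounds 1, 2 and 3 is possible, but it is not shown.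

As far as these compounds go, how far compound 4 truly lies from the other three stays unknown while only a limit stands for it, so the nitrile cannot yet be said to differ from the halogen and methyl groups at this position. Also open, from the compounds shown here alone, is whether an amine or a carboxylic acid on this aryl ring, or a longer chain in place of the single carbon linking it to the shared core, would stay equally flat.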